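The compounds below may be only part of what the source reports. "The series", "measured", "known", "first", "only" and "open" are said of these compounds alone.

Measured compounds:
compound 1, `Cc1cc(Cl)cc(-c2cc3cc(C(=N)N)ccc3[nH]2)c1`: 51000 nM
compound 2, `N=C(N)c1ccc2[nH]c(-c3cc(F)cc(Cl)c3)cc2c1`: 278000 nM
compound 3, `N=C(N)c1ccc2[nH]c(-c3cc(Cl)cc(Cl)c3)cc2c1`: 133000 nM

All three share the core of compound 1 and differ in a single group on the pendant six-membered ring. In an assay on isolated protein for inhibition of acid-sensing ion channel 3 (Homo sapiens), read by patch clamp (a higher number here means a weaker inhibitor, a lower number a stronger inhibitor), compound 3 stands second highest of the three numbers: the step of a 2.6-fold higher number from compound 1 to compound 3 (0.42 log units; beyond the scatter) and the step of a 2.1-fold lower number from compound 2 to compound 3 (0.32 log units; beyond the scatter) place it between the other two, with compound 1 giving the lowest number and compound 2 the highest after the step of a 5.5-fold higher number from compound 1 to compound 2 (0.74 log units; beyond the scatter).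

Compound 4, `N=C(N)c1ccc2[nH]c(-c3cc(N)cc(Cl)c3)cc2c1`, differs from compound 3 in one place: amino in place of chloro on an aromatic carbon. Among the compounds with values here, none of the measured steps brings in an amino group; all three exchange methyl, fluoro and chloro among themselves, and every one of them is modest in size, so the group at this place has so far shifted the number in this assay only within a narrow band. An amino group lies outside that set, so the direction of the step of a 1.1-fold higher number from compound 3 to compound 4 (0.05 log units; within the scatter) is uncertain and is expected to stay modest at most. Compound 4 is therefore estimated at 150000 nM in this assay, with a range from 40000 nM to 500000 nM.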

Compound 4, half-maximal inhibitory concentration: 95000 nM
Estimate against measurement, compound 4: 1.6-fold (0.20 log units) above, within the range that was stated.
By their numbers in this assay, from the lowest: compounds 1, 4 and 3 (each within the scatter of the next, the first and the last beyond it); then compound 2.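

In this assay, amino in place of chloro brings in 1 hydrogen-bond donor and 1 hydrogen-bond acceptor at this place, yet a 1.4-fold lower number from compound 3 to compound 4 (0.15 log units; within the scatter) stays within the scatter, as does a 1.9-fold higher number from compound 1 to compound 4 (0.27 log units; within the scatter) on the exchange with methyl, so compound 4 cannot be separated from either compound 3 or compound 1. Within the data shown here, the exchange with fluoro is the only one of the new steps that can be told apart from the scatter, with a 2.9-fold lower number from compound 2 to compound 4 (0.47 log units; beyond the scatter) being modest in size, and compound 2 remains the highest number of the four while compound 1 and compound 3 still differ beyond the scatter. Nothing available bears on why amino sits with methyl and chloro here while fluoro stands apart.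

On these data alone, it remains open whether a hydroxyl, a methoxy, a carboxylic acid or a longer chain at this place would leave the narrow band seen so far. Also open, as far as these compounds go, is whether amino would behave the same way if the chloro group that it sits meta to were replaced by another group.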